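The source may report more compounds than this note shows. Statements on the series, on what has been measured and on what is new or still open speak of the compounds shown alone.

Of the compounds shown here, three have been tested in an assay on a protein complex for inhibition of CDK8/Cyclin C (Homo sapiens), with a stated time of 1 h, tested at 10 uM; a higher number here means more inhibition at the concentration tested (going by the name of the read-out), a lower number less inhibition. Compound 1 `CCOC(=O)/C=C/c1ccncc1-c1ccc2[nH]ccc2c1` gives 100%, compound 3 `CNC(=O)/C=C/c1ccncc1-c1ccc2c(cnn2C)c1` gives 98%, and compound 2 `CC(C)[C@@H](NC(=O)/C=C/c1ccncc1-c1ccc2ccccc2c1)C(=O)O` gives 77%, the lowest of the three; its gap to compound 3 and its wider gap to compound 1 both lie beyond the usual scatter. Compound 4 `CNC(=O)/C=C/c1ccncc1-c1ccc2ccccc2c1` has not yet been measured in this assay. It differs from compound 2 in one place: methyl in place of 1-carboxy-2-methylpropyl on an amide-type nitrogen. Going by the values given here, no pair of measured compounds differing in a single spot is available to size this change directly. Still, a gain looks likely, because compound 3 with methyl on its amide-type nitrogen gives 98%. The expected step is a rise, a number 16 percentage points higher from compound 2 to compound 4 (beyond the scatter). Compound 4 is therefore expected to give about 93%, within a range of 78% to 100%.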

Compound 4, a percentage reported as inhibition, at one concentration (the size of the read-out at that concentration, not a potency): 101%
Beside the measured number, compound 4's estimate is 8 percentage points below it, outside the stated range (above it).
By their numbers in this assay, from the lowest: compound 2; then compounds 3, 1 and 4 (each within the scatter of the next).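

Going by these compounds alone, the first direct comparison at this position comes from replacing 1-carboxy-2-methylpropyl with methyl on the amide-type nitrogen: in this assay, the change gives a number 24 percentage points higher from compound 2 to compound 4 (beyond the scatter). The lower inhibition of compound 2 therefore goes with this larger group, since the rest of the two structures is the same. Nothing given here explains the size of this step.

As far as these compounds go, it remains open whether the carboxylic acid or the rest of the group accounts for the difference. How an amine on a short chain, such as 2-aminoethyl, would behave on this nitrogen is also unresolved.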